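Swapping methoxy for chloro on a core without measured toxicity

The source may hold more compounds than are shown below. What is called first, only, known or untested is meant among the compounds shown, and "the series" means these compounds.

In an ADME assay on HepG2 cells (Homo sapiens) for cytotoxicity, read by luminescence, with a stated time of 72 h (a lower number here means that less compound is needed, a higher number that more compound is needed for the effect), compound 2 `CCOC(=O)c1c(-c2cccc(Oc3ccccc3)c2)[nH]c2cc(Cl)c(OC)cc2c1=O` reaches only a limit of the assay, > 21500 nM. Compound 1 `CCOC(=O)c1c(-c2cccc(OC)c2)[nH]c2cc(Cl)c(OC)cc2c1=O` likewise stops at a limit, > 21500 nM. Both values sit at the limit of > 21500 nM in this assay, at which 2 of the 2 values shown sit, so the step that the two limits leave unreadable from compound 1 to compound 2 cannot be read. Compound 3 `CCOC(=O)c1c(-c2cccc(Oc3ccccc3)c2)[nH]c2cc(Cl)c(Cl)cc2c1=O` differs from compound 2 by chloro in place of methoxy on an aromatic carbon. Among the measured compounds shown here, no measured step bears on this change, and the two limits give no readable step size at all. Compound 3 is therefore expected to remain beyond the limit, with an estimated 30000 nM (range 10000 nM to 100000 nM). That estimate means an expected step that the limit leaves unreadable from compound 2 to compound 3.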

Compound 3, half-maximal effective concentration: > 21500 nM
Compound 3: only a limit was reported; the forecaster's own chance of this, stated with the estimate: 75%; the middle value does not contradict the limit.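

Compound 2 and compound 3 both stop at a limit of the assay rather than a number, so no new step can be read between them: the limit of > 21500 nM in this assay, at which 3 of the 3 values shown sit.

The compounds shown leave open how much of each is needed for an effect in this assay and whether chloro in place of methoxy shifts that amount at all.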